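This account rests on a few compounds, and the source may have more. Where it says the series, first, only, none or still open, it means among the compounds named here.

Values measured in a functional assay on LoVo cells (Homo sapiens) for inhibition, read by colorimetric assay and MTT assay, with a stated time of 72 h (on this read-out higher numbers stand for weaker inhibition and lower numbers for stronger inhibition), are:
Compound 1 `C=CCCCCOc1ccccc1-c1cnc(OCCC=C)n1C` gives 12000 nM
Compound 2 `C=CCCCCOc1ccc(F)cc1-c1cnc(OCCC=C)n1C` gives 38000 nM
Compound 3 `C=CCCCCOc1cc(F)ccc1-c1cnc(OCCC=C)n1C` gives 45000 nM

Compound 1 holds the lowest number of the three. Compound 4 `C=CCCCCCOc1ncc(-c2ccccc2OCCCCC=C)n1C` differs from it by pent-4-en-1-yl in place of vinyl on a saturated chain carbon, two bonds along the chain from an oxygen on an aromatic ring on a saturated chain carbon, two bonds along the chain from an oxygen on an aromatic ring. Among the compounds with values here, no measured step changes this chain. The two fluoro steps, a 3.2-fold higher number from compound 1 to compound 2 (0.50 log units; beyond the scatter) and a 3.8-fold higher number from compound 1 to compound 3 (0.57 log units; beyond the scatter) and both modest, bear on it only as a gauge of size, and both raise the number. A similarly modest rise, or none, is therefore expected in this assay and the direction remains uncertain. The expected change is a 1.3-fold higher number from compound 1 to compound 4 (0.10 log units; within the scatter) as a rough estimate. Compound 4 is estimated at 15000 nM (expected range 5000 nM to 45000 nM).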

Compound 4, half-maximal inhibitory concentration: 32000 nM
Beside the measured number, compound 4's estimate is 2.1-fold (0.33 log units) below it; the range from low to high includes it.
By their numbers in this assay, from the lowest: compound 1; then compounds 4, 2 and 3 (each within the scatter of the next).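

In this assay, pent-4-en-1-yl in place of vinyl on this saturated chain carbon gives a 2.7-fold higher number from compound 1 to compound 4 (0.43 log units; beyond the scatter), so this chain is not neutral to the number: lengthening it raises the value. The rise is modest, and compound 1 keeps the lowest number of the four. Nothing available explains the rise. The compounds shown leave open how a shorter chain, a saturated chain, or a chain ending in an amine or a carboxylic acid would read at this position. They also leave open whether fluoro and the longer chain together would add up.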